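The source may hold more compounds than are shown below. What is called first, only, known or untested is meant among the compounds shown, and "the series" means these compounds.

Measured compounds:
compound 1 `O=C(Nc1cccc(-c2ccsc2)c1)C(Cl)Cl` — > 50000 nM
compound 2 `CSc1cccc(-c2cc(NC(=O)C(Cl)Cl)cc(-c3cccc(SC)c3)c2)c1` — > 30000 nM
compound 3 `O=C(Nc1cccc(-c2cccc(F)c2)c1)C(Cl)Cl` — > 50000 nM

In a functional assay on NCI-H460 cells (Homo sapiens) for cytotoxicity, read by MTT assay, with a stated time of 68 h (on this read-out higher numbers stand for weaker inhibition and lower numbers for stronger inhibition), compound 1 gives no number, only a limit of the assay, > 50000 nM. Compound 3 likewise reaches only a limit, > 50000 nM. Compound 2 stops at a different limit, > 30000 nM. So all three measured values are limits, and compound 1 stands at the limit of > 50000 nM in this assay, at which 2 of the 3 values shown sit; the remaining value sits at the limit of > 30000 nM in this assay, at which 1 of the 3 values shown sits. Among the compounds with values here, none of the three shows measurable inhibition, and no step between measured compounds can be given, since no pair of them differs in one place.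

The step to compound 4 `O=C(Nc1cccc(-c2nccs2)c1)C(Cl)Cl` changes the five-membered ring attached to the shared core of compound 1: 1,3-thiazol-2-yl in place of thiophen-3-yl on an aromatic carbon. The dichloroacetamide and the six-membered aromatic ring of carbon only are kept.

Given that compound 1 and compound 3, with different small groups at the same place, both sit at limits, no movement beyond the usual scatter is expected for this change, and the outcome for compound 4 is estimated most likely to be another limit. Compound 4 is therefore expected at about 50000 nM, within 15000 nM to 150000 nM. The expected step is a number no higher from compound 1 to compound 4 (the limit leaves the size open).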

Compound 4, half-maximal inhibitory concentration: > 50000 nM
Compound 4: a limit, no number (the forecaster's own chance of this, stated with the estimate: 80%); the middle value lies on the limit itself.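

In this assay compound 4 gives > 50000 nM, a limit of the assay and not a number. Compound 1 also stands at a limit, so no step can be read between compound 1 and compound 4. The compounds shown leave open whether any group on the shared core would give a measurable value in this assay.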